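Swapping a basic chain for an ester on the shared core

This account rests on a few compounds, and the source may have more. Where it says the series, first, only, none or still open, it means among the compounds named here.

Compound 1 `CCCCCCOc1ccc2c(=O)cc(-c3cc(C(C)(C)C)c(O)c(C(C)(C)C)c3)oc2c1`: 5000 nM
Compound 2 `CN(C)CCCOc1ccc2c(=O)cc(-c3cc(C(C)(C)C)c(O)c(C(C)(C)C)c3)oc2c1`: 700 nM

In a functional assay for inhibition (a higher number here means a weaker inhibitor, a lower number a stronger inhibitor), compound 2 gives the lowest of the two numbers, with compound 1 nearest at 5000 nM. For the measured compounds named here, the single measured step, a 7.1-fold lower number from compound 1 to compound 2 (0.85 log units; beyond the scatter), shows that a dimethylamino at the chain end helped. Compound 3 `CCCCCOC(=O)COc1ccc2c(=O)cc(-c3cc(C(C)(C)C)c(O)c(C(C)(C)C)c3)oc2c1` carries pentyloxycarbonyl in place of 2-(dimethylamino)ethyl on a saturated chain carbon bound to an oxygen on an aromatic ring, which removes that nitrogen again and brings in an ester ending. Going by the values given here, no measured step covers this exact swap, but the loss of the nitrogen points back toward compound 1. Compound 3 is therefore expected to give a weaker result, a 4.3-fold higher number from compound 2 to compound 3 (0.63 log units; beyond the scatter), estimated at 3000 nM (range 1000 nM to 10000 nM).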

Compound 3, half-maximal inhibitory concentration: 5000 nM
Beside the measured number, compound 3's estimate is 1.7-fold (0.22 log units) below it, and the stated range covers the measured number.
By their numbers in this assay, from the lowest: compound 2; then compounds 1 and 3 (each within the scatter of the next).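

In this assay the ester ending of compound 3 does not keep the gain seen with compound 2, and the change costs a 7.1-fold higher number from compound 2 to compound 3 (0.85 log units; beyond the scatter) at this position. Set against the plain chain, pentyloxycarbonyl in place of pentyl gives no change at the digits printed from compound 1 to compound 3 (within the scatter) so these two chains without nitrogen read alike, and among these three compounds only the one with the dimethylamino group stands apart. Nothing given here explains this difference.

Still open, on these data alone, is how a carboxylic acid or a morpholine at the chain end would read, and whether a longer chain carrying the dimethylamino group would shift the number further.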